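The source may hold more compounds than are shown below. What is called first, only, known or untested is meant among the compounds shown, and "the series" means these compounds.

In an assay on isolated protein for inhibition of RAC-alpha serine/threonine-protein kinase (Homo sapiens), tested at 30 uM (a higher number here means more inhibition at the concentration tested (going by the name of the read-out), a lower number less inhibition), compound 1 `c1ccc(-[n+]2c[nH]c3ncncc32)cc1` gives 0%. Compound 2 `Fc1ccc(-[n+]2c[nH]c3ncncc32)cc1` differs from it by fluoro in place of hydrogen on an aromatic carbon, and in this assay compound 2 gives 0%. The step measured is no change at the digits printed from compound 1 to compound 2 (within the scatter). Compound 3 `Clc1ncnc2ncn(Cc3ccccc3)c12` stands on a different core; the difference between the two cores is not broken down here. In this assay compound 3 gives 0%, level with compounds 1 and 2 at the digits reported, within the scatter of repeated measurements of this kind.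

Compound 4 `Fc1ccc(Cn2cnc3ncnc(Cl)c32)cc1` has not yet been measured. It differs from compound 3 by fluoro in place of hydrogen on an aromatic carbon. Among the compounds with values here, this is the same kind of change as the one between compound 1 and compound 2, though the surroundings are not the same word for word: in compound 2 the fluoro stands para to a group of 9 heavy atoms, whereas in compound 4 it stands para to a large group. In this assay the step is expected to be no change at the digits printed from compound 3 to compound 4 (within the scatter), set beside the earlier one, no change at the digits printed from compound 1 to compound 2 (within the scatter), and this expectation rests on compound 3 giving 0% and on the earlier step showing no change within the scatter. Compound 4 is expected to give 0% in this assay, with the estimate ranging from -8% to 10%.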

Compound 4, a percentage reported as inhibition, at one concentration (the size of the read-out at that concentration, not a potency): 0%
For compound 4 middle estimate and measured number coincide at the digits printed, and the stated range covers the measured number.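

In this assay, the step on the core of compound 3 reads no change at the digits printed from compound 3 to compound 4 (within the scatter), and it agrees with the same change on the core of compound 1: the same change on two cores in this assay, no change at the digits printed (within the scatter) from compound 1 to compound 2 and no change at the digits printed (within the scatter) from compound 3 to compound 4, 0 percentage points apart, within the scatter of two such steps. Within these two pairs, then, fluoro in place of hydrogen on an aromatic carbon carries from one core to the other with no difference in this read-out. This is weak evidence of transfer, however: compound 1, compound 2 and compound 3 read the same as compound 4 at 0%, so neither step starts from any measurable inhibition, and the agreement does not show what the change would do on a compound that inhibits the protein at the concentration tested, nor does a reading at one concentration give a potency for any of them.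

The compounds shown leave open whether an amine or a carboxylic acid on that aromatic carbon, or an amine in place of the chloro group of compound 3, would give a reading different from the one all four share. They also leave open whether the fluoro step would still read the same on a compound of this series with a measurable reading to start from.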